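Aryl swap on the ring nitrogen: cytotoxicity outlook

The compounds below may be only part of what the source reports. "The series", "measured", "known", "first", "only" and "open" are said of these compounds alone.

Compound 1 `Cc1ccccc1-c1nn(-c2cc(F)ccc2F)cc1CNCCN1CCN(C)CC1` is one of two analogues measured so far in an ADME assay on Huh-7 cells (Homo sapiens) for cytotoxicity; on this read-out lower numbers stand for higher toxicity in this test and higher numbers for lower toxicity in this test. In this assay compound 1 gives > 20000 nM, which is a limit of the assay rather than a number. Compound 2 `Cc1c(CNCCN2CCN(C)CC2)c(-c2ccccc2)nn1-c1ccc(F)cc1` gives > 20000 nM in this assay, again a limit. Both values sit at the limit of > 20000 nM in this assay, at which 2 of the 2 values shown sit, so compound 1 stands at that limit alongside compound 2. Compound 3 `CSc1ccc(-n2cc(CNCCN3CCN(C)CC3)c(-c3ccccc3C)n2)cc1` differs from compound 1 by 4-(methylsulfanyl)phenyl in place of 2,5-difluorophenyl on an aromatic nitrogen. Among the compounds with values here, no measured step covers this change. The expected step is a number no higher from compound 1 to compound 3 (the limit leaves the size open), none beyond the scatter. Compound 3 is therefore estimated at 20000 nM in this assay, within 8000 nM to 50000 nM, most likely reported again as a limit.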

Compound 3, half-maximal cytotoxic concentration: 17000 nM
Compound 3: the middle estimate sits 1.2-fold (0.07 log units) above what was measured; the range from low to high includes it.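

In this assay, 4-(methylsulfanyl)phenyl in place of 2,5-difluorophenyl on an aromatic nitrogen gives an at least 1.1-fold lower number from compound 1 to compound 3 (0.07 log units; that floor lies within the scatter). Within the data shown here, compound 3 thus provides the first actual number, showing that this position can carry a group that gives a value rather than a limit, though the step has no upper bound and its true size remains unknown. The read-out is still dominated by the limit: the limit of > 20000 nM in this assay, at which 2 of the 3 values shown sit.

On these data alone, whether a phenyl bearing an amine or a carboxylic acid at this position would give a step beyond the scatter remains open. The same holds for a longer chain on the sulfur.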